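This account rests on a few compounds, and the source may have more. Where it says the series, first, only, none or still open, it means among the compounds named here.

Measured in a functional assay on M21 cells (Homo sapiens) for antiproliferative activity, read by sulforhodamine B assay, with a stated time of 48 h; a higher number here means a weaker inhibitor, a lower number a stronger inhibitor:
- compound 1 `CN1CCN(c2ccc(S(=O)(=O)Oc3c(Cl)cc(Cl)cc3Cl)cc2)C1=O`: 1700 nM
- compound 2 `CN1CCN(c2ccc(S(=O)(=O)Oc3ccc(F)cc3)cc2)C1=O`: > 100000 nM (a limit)
- compound 3 `CCCN1CCN(c2ccc(S(=O)(=O)Oc3c(Cl)cc(Cl)cc3Cl)cc2)C1=O`: 56000 nM

Of the two exact numbers, compound 3 holds the higher, with a 33-fold higher number from compound 1 to compound 3 (1.52 log units; beyond the scatter). Next is compound 4 `CCCN1CCN(c2ccc(S(=O)(=O)Oc3ccc(F)cc3)cc2)C1=O`, with 4-fluorophenyl in place of 2,4,6-trichlorophenyl on an oxygen. Among the compounds with values here, the same exchange separates compound 1 from compound 2, and no sized step exists for it. Compound 1 reads 1700 nM. Compound 2 gives > 100000 nM, which is a limit. A move to a higher number is therefore expected in this assay, and the expected change is a 2.9-fold higher number from compound 3 to compound 4 (0.46 log units; beyond the scatter). For compound 4 the estimate is 160000 nM, with an expected range of 70000 nM to 400000 nM.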

Compound 4, half-maximal inhibitory concentration: 14000 nM
For compound 4 the middle estimate is 11-fold (1.06 log units) above the measured one; the whole stated range lies above it.
By their numbers in this assay, from the lowest: compound 1; then compound 4; then compound 3. At a limit, above all of these: compound 2.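

The group on the oxygen now has a sized step: 4-fluorophenyl in place of 2,4,6-trichlorophenyl gives a 4.0-fold lower number from compound 3 to compound 4 (0.60 log units; beyond the scatter) in this assay, opposite in direction to what the printed values of compound 1 and compound 2 show. The ethyl change also reverses with the group on the oxygen, with an at least 7.1-fold lower number from compound 2 to compound 4 (0.85 log units; beyond the scatter), so the two places do not read independently in these four compounds: the same change on two cores in this assay, a 33-fold higher number (1.52 log units; beyond the scatter) from compound 1 to compound 3 and an at least 7.1-fold lower number (0.85 log units; beyond the scatter) from compound 2 to compound 4, at least 230-fold (2.37 log units) apart, beyond the scatter of two such steps Compound 2 gives > 100000 nM, which is a limit: the limit of > 100000 nM in this assay, at which 1 of the 4 values shown sits.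

Open, as far as these compounds go, is how a longer chain or a carboxylic acid would read in place of the ethyl. Also open, from the compounds shown here alone, is whether the reversal holds with a 4-chlorophenyl on the oxygen.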